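The source may report more compounds than this note shows. Statements on the series, on what has been measured and on what is new or still open speak of the compounds shown alone.

In a functional assay on KB cells (Homo sapiens) for cytotoxicity, read by spectrophotometry and crystal violet staining (on this read-out lower numbers stand for stronger inhibition and higher numbers for weaker inhibition), compound 1 (`C[C@H]1OC(n2c(Cl)c(C#N)c3cc(Cl)c(Cl)cc32)[C@H](O)[C@@H]1O`) gives 40000 nM and compound 2 (`[N-]=[N+]=NC[C@H]1OC(n2c(Cl)c(C=O)c3cc(Cl)c(Cl)cc32)[C@H](O)[C@@H]1O`) gives 25000 nM, so these two values lie within the usual scatter of each other. Compound 3 (`N#Cc1c(Cl)n(C2O[C@H](CN=[N+]=[N-])[C@@H](O)[C@H]2O)c2cc(Cl)c(Cl)cc12`) departs from compound 2 in one place, with cyano in place of formyl on an aromatic carbon. Going by the values given here, no measured pair shows this change alone. Compound 1 also carries cyano and gives 40000 nM, so no step beyond the scatter is expected in this assay. An estimated 1.2-fold higher number from compound 2 to compound 3 (0.08 log units; within the scatter) would stay within that scatter. For compound 3 the expected value is 30000 nM (range 10000 nM to 80000 nM).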

Compound 3, half-maximal inhibitory concentration: 60000 nM
For compound 3 the middle estimate is 2.0-fold (0.30 log units) below the measured one; the measured number falls inside the stated range.
By their numbers in this assay, from the lowest: compounds 2, 1 and 3 (each within the scatter of the next, the first and the last beyond it).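

In this assay, going by these compounds alone, cyano in place of formyl on an aromatic carbon gives a 2.4-fold higher number from compound 2 to compound 3 (0.38 log units; beyond the scatter) and this modest step is the first here beyond the scatter, so at this position formyl goes with the stronger inhibition of the two. Azido in place of hydrogen on a saturated chain carbon gives a 1.5-fold higher number from compound 1 to compound 3 (0.18 log units; within the scatter) and so cannot be told apart from repeat scatter. Nothing measured here explains the formyl step.

As far as these compounds go, whether a carboxylic acid or an amine on this aromatic carbon would give a lower or higher number remains open. So does whether formyl keeps its edge over cyano when the azido group is absent.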